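The compounds below may be only part of what the source reports. "The series", "measured", "known", "first", "only" and "open" are said of these compounds alone.

The study rests on a small set of compounds sharing one core. Compound 1 `O=CN1CCN(c2ccc(Cl)cc2)C1=S` carries a 4-chlorophenyl on the ring nitrogen, while compound 2 `N#C/C(=C\N1CCN(C(=O)c2ccco2)C1=S)C(N)=O` and compound 3 `O=CN1CCN(C(=O)c2ccco2)C1=S` carry a furoyl group there and differ in what sits on the other ring nitrogen. In a functional assay on DU-145 cells (Homo sapiens) for inhibition, read by sulforhodamine B assay, with a stated time of 48 h (on this read-out higher numbers stand for weaker inhibition of growth and lower numbers for stronger inhibition of growth), compound 1 gives 15700 nM, compound 2 gives 29800 nM, and compound 3 gives 2500 nM. Compound 2 thus holds the highest number of the three, though the gap to compound 1 lies within the usual scatter of this assay, so the two cannot be told apart; the gap to compound 3 lies beyond it, and compound 3 shows the lower number.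

Compound 4 `N#C/C(=C\N1CCN(C(=O)c2ccco2)C1=S)C(=O)Nc1ccc(Cl)cc1` has not yet been measured in this assay. It differs from compound 2 in one place: 4-chlorophenyl in place of hydrogen on an amide-type nitrogen. Among the measured compounds shown here, no measured pair shows this change, so its effect is unknown. Since compound 1 already carries a 4-chlorophenyl and gives 15700 nM, a number in a similar region is plausible. The step from compound 2 to compound 4 is expected to be modest and downward, a 3.0-fold lower number from compound 2 to compound 4 (0.47 log units; beyond the scatter). Compound 4 is therefore expected to give about 10000 nM in this assay, with a range from 3000 nM to 40000 nM.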

Compound 4, concentration for 50% growth inhibition: 15900 nM
Compound 4: the middle estimate sits 1.6-fold (0.20 log units) below what was measured; low and high end bracket the measured number.
By their numbers in this assay, from the lowest: compound 3; then compounds 1, 4 and 2 (each within the scatter of the next).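

Among the compounds shown here, compound 4 gives the first matched pair at this position: 4-chlorophenyl in place of hydrogen on an amide-type nitrogen amounts to a 1.9-fold lower number from compound 2 to compound 4 (0.27 log units; within the scatter) in this assay, so the two compounds cannot be told apart on this read-out. The primary amide of compound 2 is therefore not needed to keep the number in this region, and replacing the amide hydrogen with a whole aromatic ring leaves growth inhibition at a level that the assay does not distinguish from the original. This is one step at one position, however, and the compounds shown offer no measurement that would account for the outcome.

The compounds shown leave open whether a plain phenyl without the chlorine, a methyl or a longer alkyl chain on the same nitrogen would also leave the number unresolved from that of compound 2, or whether one of them would move it beyond the scatter. They also leave open whether the same change would behave alike if a benzoyl group stood in place of the furoyl group.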